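Swapping bromo for nitro on the chalcone aryl ring

The compounds below may be only part of what the source reports. "The series", "measured", "known", "first", "only" and "open" are said of these compounds alone.

Compound 1 `O=C(COc1ccc(C(=O)/C=C/c2ccccc2Cl)cc1)N[C@H]1CCOC1=O`: 3240 nM
Compound 2 `O=C(COc1ccc(C(=O)/C=C/c2ccc(F)c(F)c2)cc1)N[C@H]1CCOC1=O`: 19800 nM
Compound 3 `O=C(COc1ccc(C(=O)/C=C/c2cccc(Br)c2)cc1)N[C@H]1CCOC1=O`: 9800 nM

These three compounds were tested in a functional assay on DU-145 cells (Homo sapiens) for antiproliferative activity, read by MTT assay, with a stated time of 72 h; a lower number here means a stronger inhibitor, a higher number a weaker inhibitor. Compound 3 sits second highest of the three: a 3.0-fold higher number from compound 1 to compound 3 (0.48 log units; beyond the scatter), while a 2.0-fold lower number from compound 2 to compound 3 (0.31 log units; beyond the scatter).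

Compound 4 `O=C(COc1ccc(C(=O)/C=C/c2cccc([N+](=O)[O-])c2)cc1)N[C@H]1CCOC1=O` differs from compound 3 by nitro in place of bromo on an aromatic carbon, cut one bond further out, 3-bromophenyl to 3-nitrophenyl. Among the compounds with values here, no measured pair exchanges these two groups. The swaps that were measured on this ring, a 6.1-fold higher number from compound 1 to compound 2 (0.79 log units; beyond the scatter) and a 3.0-fold higher number from compound 1 to compound 3 (0.48 log units; beyond the scatter), were modest in size, so a modest step in either direction, or none beyond the scatter, is expected here as well: a 1.0-fold higher number from compound 3 to compound 4 (0.01 log units; within the scatter). Compound 4 is therefore estimated at 10000 nM, in the range 3500 nM to 30000 nM.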

Compound 4, half-maximal inhibitory concentration: 41800 nM
Beside the measured number, compound 4's estimate is 4.2-fold (0.62 log units) below it; measured number outside the range, above it.
By their numbers in this assay, from the lowest: compound 1; then compound 3; then compound 2; then compound 4.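

Within the data shown here, on the same aromatic carbon, nitro and bromo are not interchangeable, with a 4.3-fold higher number from compound 3 to compound 4 (0.63 log units; beyond the scatter) in this assay as the first measured exchange of these two groups. Compound 4 is the weakest of the four, shown by a 2.1-fold higher number from compound 2 to compound 4 (0.32 log units; beyond the scatter) and by a 13-fold higher number from compound 1 to compound 4 (1.11 log units; beyond the scatter) which is the only large step so far. Nothing measured here explains this drop.

As far as these compounds go, whether an amine or a methoxy group on this carbon would land nearer compound 3 or compound 4 stays open. A single nitro compound also cannot show whether the result holds on other carbons of the ring.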